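Adding an Ethyl Group to a Five-Membered Ring Core

This account rests on a few compounds, and the source may have more. Where it says the series, first, only, none or still open, it means among the compounds named here.

Compound 3 `CC1CC(=O)N(CC(=O)N2CCN(c3ccc(F)cc3)CC2)C1=O` gives 300 mg/kg in a functional assay on the whole organism (strain CD1) with Mus musculus as the target, in the maximal electroshock model, with a stated time of 0.5 h (a lower number here means that less compound is needed, a higher number that more compound is needed for the effect), the highest of the three numbers measured. Compound 1 `CCC1(C)CC(=O)N(CC(=O)N2CCN(c3ccccc3Cl)CC2)C1=O` gives 100 mg/kg, and compound 2 `CCC1(C)CC(=O)N(CC(=O)N2CCN(c3ccccc3C)CC2)C1=O` gives 100 mg/kg; the step of no change at the digits printed from compound 1 to compound 2 (within the scatter) shows that the aromatic substituent exchange made no difference within the scatter. Compound 4 `CCC1(C)CC(=O)N(CC(=O)N2CCN(c3ccc(F)cc3)CC2)C1=O` differs from compound 3 in one place: ethyl in place of hydrogen on a saturated ring carbon. Among the measured compounds shown here, no measured step isolates this change, since compound 1 and compound 2 carry the ethyl group but also a different aromatic substituent. Both of those compounds nonetheless sit well below compound 3, which makes a lower number plausible. A moderate drop is therefore expected, a 3.0-fold lower number from compound 3 to compound 4 (0.48 log units; beyond the scatter). Compound 4 is estimated at 100 mg/kg, within a range from 50 mg/kg to 300 mg/kg.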

Compound 4, minimum effective dose: 100 mg/kg
The estimate for compound 4 equals the measured number at the digits printed; low and high end bracket the measured number.
By their numbers in this assay, from the lowest: compounds 1, 2 and 4 (each within the scatter of the next); then compound 3.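

In this assay the ethyl group on the saturated ring carbon is now isolated, as a 3.0-fold lower number from compound 3 to compound 4 (0.48 log units; beyond the scatter) appears with the 4-fluorophenyl group held fixed. Changing the group on the amine nitrogen gives no change at the digits printed from compound 2 to compound 4 (within the scatter) for 4-fluorophenyl in place of 2-methylphenyl and no change at the digits printed from compound 1 to compound 4 (within the scatter) for 4-fluorophenyl in place of 2-chlorophenyl, so among these compounds only the ethyl step goes beyond the scatter. No measured evidence bears on why the ethyl group has this effect.

From the compounds shown here alone, whether a longer chain such as propyl on that ring carbon would lower the number further remains open. So does the effect of an amine or a carboxylic acid there.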